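A few compounds are considered here, and "the series" means these few. Any claim that something is new, unique, unknown or untested is made for them only; others in the source may bear on it.

Compound 1 `Cc1ccc2c(c1)/C(=C1\SC(N3N=C(c4ccccc4)CC3c3ccc(Cl)cc3)=NC1=O)C(=O)N2` gives 240 nM in a functional assay on cells (Cancer cell lines, Homo sapiens) for cytotoxicity, read by sulforhodamine B assay, with a stated time of 48 h; a lower number here means a stronger inhibitor of growth, a higher number a weaker inhibitor of growth.
Compound 2 `COc1ccc(-c2cc(-c3ccc(Cl)cc3)n(C3C(=O)Nc4ccc(Br)cc43)n2)cc1` gives 9200 nM.
Compound 3 `COc1ccc(-c2cc(-c3ccc(Cl)cc3)n(C3C(=O)Nc4ccc(Cl)cc43)n2)cc1` gives 3750 nM.

Compound 2 stands at the highest number of the three, so it is the weakest growth inhibitor here; its nearest neighbour is compound 3, and compound 1, built on a different core, lies far lower. Among the compounds with values here, the one step that links two measured compounds is the change a 2.5-fold lower number from compound 2 to compound 3 (0.39 log units; beyond the scatter), which touches only the halogen on the bicyclic part of the shared core.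

Compound 4 `O=C1Nc2ccc(Br)cc2C1n1nc(-c2ccc3ccccc3c2)cc1-c1ccc(Cl)cc1` is derived from compound 2 by the change (naphthalen-2-yl in place of 4-methoxyphenyl on an aromatic carbon). Within the data shown here, no measured pair shows what swapping the aryl group on the five-membered ring does; the measured step from compound 2 to compound 3 concerns another position and bears only indirectly on this change. Compound 4 is therefore expected to land near compound 2, with a step of a 1.5-fold lower number from compound 2 to compound 4 (0.19 log units; within the scatter) that may or may not exceed the scatter. The estimate for compound 4 in this assay is 6000 nM, with a range from 2000 nM to 20000 nM.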

Compound 4, concentration for 50% growth inhibition: 2500 nM
Compound 4: middle estimate off by 2.4-fold (0.38 log units), on the high side, within the range that was stated.
By their numbers in this assay, from the lowest: compound 1; then compounds 4 and 3 (each within the scatter of the next); then compound 2.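

In this assay, within the data shown here, the change from 4-methoxyphenyl to naphthalen-2-yl gives a 3.7-fold lower number from compound 2 to compound 4 (0.57 log units; beyond the scatter), the first measured evidence that the aryl group on the five-membered ring affects growth inhibition. With the bromo core of this pair, the larger all-carbon group gives the stronger inhibitor, so the hydrogen-bond acceptor of 4-methoxyphenyl is not required for this level of activity. No measurement here accounts for the gain.

With only one swap shown at this position, it remains open whether a plain phenyl, or a phenyl bearing an amine or a carboxylic acid, would move the number in the same direction. On these data alone, it also remains open whether naphthalen-2-yl would give a similar step on the chloro core of compound 3.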